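Working notes: bromo to ethoxycarbonyl in compound 3

The source may report more compounds than this note shows. Statements on the series, on what has been measured and on what is new or still open speak of the compounds shown alone.

In a functional assay on HeLa cells (Homo sapiens) for cytotoxicity, read by sulforhodamine B assay (a lower number here means a stronger inhibitor, a higher number a weaker inhibitor), compound 1 (`CC(NS(=O)(=O)c1ccc(Cl)cc1)C1=CC(=O)c2c(O)ccc(O)c2C1=O`) gives 810 nM, and compound 2 (`CC(NS(=O)(=O)c1ccc(Br)cc1)C1=CC(=O)c2c(O)ccc(O)c2C1=O`) gives 5210 nM, the higher of the two numbers. Compound 3 (`CCOC(=O)c1ccc(S(=O)(=O)NC(C)C2=CC(=O)c3c(O)ccc(O)c3C2=O)cc1`) has ethoxycarbonyl in place of bromo on an aromatic carbon, para to a large group: ethoxycarbonyl in place of bromo on an aromatic carbon. Among the measured compounds shown here, the only measured step at this place, a 6.4-fold higher number from compound 1 to compound 2 (0.81 log units; beyond the scatter), exchanges one halogen for another and was modest, so it shows sensitivity there but gives no direction for an ester. A small shift toward compound 1 is expected, with the estimated change being a 1.7-fold lower number from compound 2 to compound 3 (0.24 log units; within the scatter). The estimate in this assay for compound 3 is 3000 nM, with an expected range of 800 nM to 11000 nM.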

Compound 3, half-maximal inhibitory concentration: 2260 nM
Compound 3: the middle estimate sits 1.3-fold (0.12 log units) above what was measured; measured number inside the range.
By their numbers in this assay, from the lowest: compound 1; then compound 3; then compound 2.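

Among the compounds shown here, the position para to a large group accepts ethoxycarbonyl, the first group here that is not a halogen, with a 2.3-fold lower number from compound 2 to compound 3 (0.36 log units; beyond the scatter) in this assay and so the number does not simply rise as the group grows beyond bromo. Chloro still keeps the lowest number, with a 2.8-fold higher number from compound 1 to compound 3 (0.45 log units; beyond the scatter) and so the ester does not recover the level of compound 1. Nothing available explains this order.

Still open, as far as these compounds go, is how a carboxylic acid, an amine or a longer ester chain would read at this position. Fluoro would show whether the gap between the two halogens extends to a third.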